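A few compounds are considered here, and "the series" means these few. Any claim that something is new, unique, unknown or untested is made for them only; others in the source may bear on it.

Compound 1 `CCCOC(=O)CCC(=O)N1CCN(CCCOc2cc3c(Nc4ccc(F)c(Cl)c4)ncnc3cc2OC)CC1` gives 70.4% in a functional assay on A549 cells (Homo sapiens) for cytotoxicity, read by MTT assay, with a stated time of 24 h, tested at 60 uM (on this read-out higher numbers stand for a weaker effect at the one concentration tested and lower numbers for a stronger effect), the higher of the two numbers measured, so it shows the weaker effect at this concentration. Compound 2 `CCCCCOC(=O)CCC(=O)N1CCN(CCCOc2cc3c(Nc4ccc(F)c(Cl)c4)ncnc3cc2OC)CC1` gives 30% in this assay. For the measured compounds named here, the one measured step, a number 40.4 percentage points lower from compound 1 to compound 2 (beyond the scatter), is large and beyond the scatter. Compound 3 `CCCCCCCCCCCCCOC(=O)CCC(=O)N1CCN(CCCOc2cc3c(Nc4ccc(F)c(Cl)c4)ncnc3cc2OC)CC1` differs from compound 1 by decyl in place of hydrogen on a saturated chain carbon, three bonds along the chain from an oxygen next to a carbonyl group, a longer group entering where compound 2 carries ethyl. For compound 3 a lowering step is therefore expected, a number 45.4 percentage points lower from compound 1 to compound 3 (beyond the scatter), though its size is uncertain. Compound 3 is estimated at 25% in this assay, between 5% and 55%.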

Compound 3, a percentage reported as activity, at one concentration (the size of the read-out at that concentration, not a potency): 20.6%
The estimate for compound 3 lay 4.4 percentage points above the measured number; low and high end bracket the measured number.
By their numbers in this assay, from the lowest: compounds 3 and 2 (each within the scatter of the next); then compound 1.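

Decyl on this saturated chain carbon gives a number 49.8 percentage points lower from compound 1 to compound 3 (beyond the scatter) in this assay, so the large step seen with ethyl is not limited to that one group. Going further out along the chain, octyl gives a number 9.4 percentage points lower from compound 2 to compound 3 (within the scatter), so the added length brings no readable change between these two compounds. Nothing at hand explains either step.

Open, going by these compounds, is how a group of intermediate size, such as butyl, would behave here. Also open, on these data alone, is whether a chain ending in an amine or a carboxylic acid would give a similar number.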